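The source may hold more compounds than are shown below. What is called first, only, known or untested is meant among the compounds shown, and "the series" means these compounds.

Compound 2 `Nc1ccccc1NC(=O)c1ccc(NC(=S)NCc2cncc(F)c2)cc1` is known in an assay on isolated protein for inhibition of Nicotinamide phosphoribosyltransferase (Homo sapiens), read by fluorescence, with stated times of 5 min and 15 min (on this read-out higher numbers stand for weaker inhibition and lower numbers for stronger inhibition), only as a limit, > 2000 nM. Compound 1 `Nc1ccccc1NC(=O)c1ccc(NC(=S)NCc2cccc(F)c2)cc1` likewise gives a limit in this assay, > 2000 nM. The step that the two limits leave unreadable from compound 1 to compound 2 stays unreadable, with both values sitting at the limit of > 2000 nM in this assay, at which 2 of the 2 values shown sit. Compound 3 `Nc1ccccc1NC(=O)c1ccc(NC(=S)NCc2cccc(Cl)c2)cc1` carries 3-chlorophenyl in place of 5-fluoropyridin-3-yl on a saturated chain carbon bound to an amide-type nitrogen. For the measured compounds named here, no measured step here has a readable size, so no shift beyond the scatter is expected for a step that the limit leaves unreadable from compound 2 to compound 3, and a further limit is the likelier outcome. Compound 3 is therefore estimated at 3000 nM, in the range 1200 nM to 20000 nM.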

Compound 3, half-maximal inhibitory concentration: > 2000 nM
Compound 3 ended at the assay's limit; the forecaster's own chance of this, stated with the estimate: 75%; the middle value is on the limit's open side.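

No step among compound 1, compound 2 and compound 3 can be read, as all three values are limits in this assay: the limit of > 2000 nM in this assay, at which 3 of the 3 values shown sit.

From the compounds shown here alone, whether 3-fluorophenyl, 5-fluoropyridin-3-yl and 3-chlorophenyl differ at all in their effect on inhibition remains open.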